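Aryl sulfone swap and rat microsomal clearance

The compounds below may be only part of what the source reports. "The series", "measured", "known", "first", "only" and "open" are said of these compounds alone.

Measured compounds:
compound 1 `O=S(=O)(c1cc(Cl)cc(Cl)c1)c1cnc2cc(F)ccc2c1-c1ccc(Cl)cc1`: 0.77 mL/min
compound 2 `O=S(=O)(c1ccc(F)c(Cl)c1)c1cnc2cc(F)ccc2c1-c1ccc(F)cc1`: 0.89 mL/min

Both measured compounds were run in an ADME assay on microsomes from liver (Rattus norvegicus) for metabolic stability, tested at 2.5 uM; a higher number here means faster removal of the compound, a lower number slower removal. Compound 1 gives 0.77 mL/min there, and compound 2 gives 0.89 mL/min. Compound 2 is the higher of the two figures, but its gap to compound 1 lies within the scatter, so the pair sits at one level and no order can be read from it.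

Compound 3 `O=S(=O)(c1cc(Cl)cc(Cl)c1)c1cnc2cc(F)ccc2c1-c1ccc(F)cc1` has not yet been measured in this assay. Relative to compound 2 the change is 3,5-dichlorophenyl in place of 3-chloro-4-fluorophenyl on a sulfonyl sulfur. Compound 3 thus shares with compound 1 the 3,5-dichlorophenyl on the sulfonyl sulfur and with compound 2 the rest of the structure. Among the compounds with values here, no step between measured compounds that differ in a single place is available, so the effect of this sulfonyl aryl change has no direct precedent here; what is available is that compound 1, carrying the entering group, gives 0.77 mL/min, at the same level as compound 2.

The expectation is therefore a step of a 1.1-fold lower number from compound 2 to compound 3 (0.04 log units; within the scatter), none beyond the scatter. Compound 3 is estimated at 0.82 mL/min, with a range from 0.5 mL/min to 1.35 mL/min.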

Compound 3, intrinsic clearance in a liver preparation (reported as CLH), per the amount of preparation that the assay uses: 1.15 mL/min
Beside the measured number, compound 3's estimate is 1.4-fold (0.15 log units) below it; the range from low to high includes it.
By their numbers in this assay, from the lowest: compounds 1, 2 and 3 (each within the scatter of the next).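

Notes on the series: in this assay the first single-place comparisons are now available, and on the sulfonyl sulfur 3,5-dichlorophenyl in place of 3-chloro-4-fluorophenyl gives a 1.3-fold higher number from compound 2 to compound 3 (0.11 log units; within the scatter) and so leaves the read-out at one level. The second comparison, fluoro in place of chloro on an aromatic carbon, gives a 1.5-fold higher number from compound 1 to compound 3 (0.17 log units; within the scatter) and likewise stays at one level, so neither place has yet shown a change in this read-out beyond repeat-measurement scatter across the groups compared. No measurement is available that bears on what sets these numbers.

From the compounds shown here alone, all three compounds carry only chloro- and fluoro-substituted phenyl groups on the shared core, so the read-out for a sulfonyl aryl group bearing an amine, a carboxylic acid or a methoxy group remains open. Also open, going by these compounds, is whether replacing the phenyl on the sulfonyl sulfur with a pyridine, or the fluoro on the aromatic carbon with a nitrile, would move the number beyond the scatter.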